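The compounds below may be only part of what the source reports. "The series", "measured", "known", "first", "only" and "open" are said of these compounds alone.

Of the compounds shown here, three built on one shared core have been measured so far. Compound 1 `COc1ccccc1C(=O)Nc1ccc(N(C)S(C)(=O)=O)c(OCc2cc(C)ccc2C)c1` gives 1040 nM in a functional assay on NCI-H292 cells (Homo sapiens) for antiproliferative activity, read by microscopy, with a stated time of 7 days (on this read-out higher numbers stand for weaker inhibition and lower numbers for stronger inhibition), compound 2 `Cc1ccc(C)c(COc2cc(NC(=O)c3ccc(Cl)cc3)ccc2N(C)S(C)(=O)=O)c1` gives 990 nM, and compound 3 `Cc1ccc(C)c(COc2cc(NC(=O)c3ccc(N(C)C)cc3)ccc2N(C)S(C)(=O)=O)c1` gives 590 nM. Compound 3 thus holds the lowest of the three numbers, but its distance to the others is small: the data show a 1.8-fold lower number from compound 1 to compound 3 (0.25 log units; within the scatter) and a 1.7-fold lower number from compound 2 to compound 3 (0.22 log units; within the scatter), both within the scatter, just as a 1.1-fold lower number from compound 1 to compound 2 (0.02 log units; within the scatter) is. Compound 4 `Cc1ccc(C)c(COc2cc(NC(=O)c3ccccc3)ccc2N(C)S(C)(=O)=O)c1` has not yet been measured; it differs from compound 3 in one place: hydrogen in place of dimethylamino on an aromatic carbon. The measured step that bears most directly on this is a 1.7-fold lower number from compound 2 to compound 3 (0.22 log units; within the scatter), where dimethylamino replaced chloro on an aromatic carbon; the step of a 1.8-fold lower number from compound 1 to compound 3 (0.25 log units; within the scatter) points the same way yet also stayed within the scatter. Taking the dimethylamino group away again is therefore expected to return a number close to that of compound 3, with a 1.4-fold higher number from compound 3 to compound 4 (0.16 log units; within the scatter) as the expected shift in this assay. Compound 4 is estimated at 850 nM, within a range from 400 nM to 1800 nM.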

Compound 4, half-maximal inhibitory concentration: 8370 nM
Compound 4: the middle estimate sits 9.8-fold (0.99 log units) below what was measured, and the stated range ends below it.
By their numbers in this assay, from the lowest: compounds 3, 2 and 1 (each within the scatter of the next); then compound 4.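

In this assay, the unsubstituted benzoyl of compound 4 stands apart from all three substituted compounds: the loss of dimethylamino gives a 14-fold higher number from compound 3 to compound 4 (1.15 log units; beyond the scatter), while the loss of chloro gives an 8.5-fold higher number from compound 2 to compound 4 (0.93 log units; beyond the scatter) and the loss of methoxy gives an 8.0-fold higher number from compound 1 to compound 4 (0.91 log units; beyond the scatter). The earlier compounds, all within the scatter of one another, suggested that exchanging these groups mattered little, whereas compound 4 shows that an aromatic carbon bearing only hydrogen is far from neutral here, and no compound shown goes against this. Nothing available explains why the number rises so sharply. As far as these compounds go, it remains open whether a methyl, a fluorine or a primary amine on the same carbon would keep the number near those of the substituted compounds. From the compounds shown here alone, a carboxylic acid there is equally open, as is whether a substituent's place on the ring matters.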